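This account rests on a few compounds, and the source may have more. Where it says the series, first, only, none or still open, it means among the compounds named here.

Measured compounds:
- compound 1, `CN(C)c1ccc(-c2nc3c(s2)C(O)CNC3)cc1`, gives 170 nM in a functional assay on MDA-MB-361 cells (Homo sapiens) for cytotoxicity, read by sulforhodamine B assay, with a stated time of 2 days; on this read-out lower numbers stand for stronger inhibition and higher numbers for weaker inhibition
- compound 2, `OCc1cc(N2CCCC2)ccc1-c1nc2c(s1)C(O)CCC2`, gives 32 nM in this assay
- compound 3, `OC1CCCc2nc(-c3ccc(N4CCCC4)cc3)sc21`, gives 200 nM in this assay

Compound 2 stands lowest of the three numbers shown, with compound 1 and compound 3 both well beyond the scatter above it. The change that leads to the unmeasured compound 4, `CN(C)c1ccc(-c2nc3c(s2)C(O)CCC3)c(CO)c1`, is dimethylamino in place of pyrrolidin-1-yl on an aromatic carbon, on an aromatic carbon of a six-membered aromatic ring of carbon only. Among the compounds with values here, no measured step covers this exchange directly. Within the data shown here, the one step on record, a 6.3-fold higher number from compound 2 to compound 3 (0.80 log units; beyond the scatter), concerns the hydroxymethyl group instead and shows that removing it costs potency; compound 4 keeps that group. Compound 1 carries dimethylamino and compound 3 carries pyrrolidin-1-yl, and their values lie within the scatter of each other, yet they also differ in their shared core, so nothing firm follows. The expected outcome is therefore a step of a 1.6-fold higher number from compound 2 to compound 4 (0.19 log units; within the scatter) in this assay of little size, if any. Compound 4 is estimated at 50 nM, within a range from 15 nM to 170 nM.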

Compound 4, half-maximal inhibitory concentration: 420 nM
For compound 4 the middle estimate is 8.4-fold (0.92 log units) below the measured one; the measured number lies above the stated range.
By their numbers in this assay, from the lowest: compound 2; then compounds 1 and 3 (each within the scatter of the next); then compound 4.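

In this assay, the aromatic carbon para to a large group proves sensitive to its amine: dimethylamino in place of pyrrolidin-1-yl gives a 13-fold higher number from compound 2 to compound 4 (1.12 log units; beyond the scatter), a large loss of inhibition. Within the data shown here, the earlier compounds could not show this, since compound 1 and compound 3 carry these two amines but also differ in their cores, whereas here the amine is the only change. Nothing shown accounts for the size of this step.

As far as these compounds go, it remains open whether the ring itself or the number of heavy atoms matters; diethylamino, an open chain, and azetidin-1-yl, a ring, would help separate the two. Also open, from the compounds shown here alone, is whether the same exchange costs as much in a compound lacking the hydroxymethyl group.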